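Amino to methylselenium swap on the series core

The compounds below may be only part of what the source reports. "The series", "measured", "known", "first", "only" and "open" are said of these compounds alone.

compound 1 `COc1ccc2c(/C=C/C(=O)c3cc(N)c(OC)c(OC)c3)c[nH]c2c1` gives 368 nM
compound 2 `COc1ccc2c(/C=C/C(=O)c3cc(N)c(OC)c(OC)c3)cn(C)c2c1` gives 455 nM
compound 3 `COc1cc(C(=O)/C=C/c2c[nH]c3ccccc23)cc(N)c1OC` gives 577 nM

In a functional assay on HCT-8 cells (Homo sapiens) for antiproliferative activity, read by MTT assay, with a stated time of 48 h (on this read-out lower numbers stand for stronger inhibition and higher numbers for weaker inhibition), compound 1 stands level with its two neighbours: a 1.2-fold higher number from compound 1 to compound 2 (0.09 log units; within the scatter) and a 1.6-fold higher number from compound 1 to compound 3 (0.20 log units; within the scatter) both stay within the scatter. Compound 4 `COc1ccc2c(/C=C/C(=O)c3cc(OC)c(OC)c([Se]C)c3)c[nH]c2c1` differs from compound 1 by a group of 2 heavy atoms (1 carbon, 1 selenium; no ring) in place of one nitrogen atom, on an aromatic carbon and neither measured step touches that amino group. For the measured compounds named here, those two small steps show only that this core tolerated changes elsewhere. Going by the values given here, no measured compound carries selenium, so the data give no direction for this change and a wide range is kept. The expected step is a 1.2-fold lower number from compound 1 to compound 4 (0.09 log units; within the scatter) and it stays uncertain. For compound 4 the estimate is 300 nM with an expected range of 50 nM to 1200 nM in this assay as the working figure.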

Compound 4, half-maximal inhibitory concentration: 78 nM
Compound 4: middle estimate off by 3.8-fold (0.59 log units), on the high side; measured number inside the range.
By their numbers in this assay, from the lowest: compound 4; then compounds 1, 2 and 3 (each within the scatter of the next).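

For the compounds shown here, replacing the amino group with methylselenium on this aromatic carbon gives a 4.7-fold lower number from compound 1 to compound 4 (0.67 log units; beyond the scatter) in this assay, the only step so far that lies beyond the scatter. This position therefore responds to its substituent in a way the two earlier changes elsewhere on the core did not show, and activity here does not depend on keeping the amino group. Nothing available accounts for the gain.

On these data alone, whether selenium itself matters remains open, and a methylthio group at this carbon would test that. Also open, as far as these compounds go, is whether methyl on the aromatic nitrogen still has so little effect with methylselenium in place.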